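The source may hold more compounds than are shown below. What is called first, only, known or untested is meant among the compounds shown, and "the series" means these compounds.

Measured so far in an assay on isolated protein for displacement of a labelled ligand from metabotropic glutamate receptor 5 (Homo sapiens), with a stated time of 60 min, tested at 1 uM; on this read-out higher numbers stand for more inhibition at the one concentration tested (going by the name of the read-out) and lower numbers for less inhibition: compound 1, `Cc1ccc(S(=O)(=O)c2cnc3cc(F)ccc3c2N2CCC(C)CC2)cc1C`, gives 90%; compound 2, `CC1CCN(c2c(S(=O)(=O)c3ccc(Cl)c(Cl)c3)cnc3cc(F)ccc23)CC1`, gives 94%; compound 3, `Cc1ccc(S(=O)(=O)c2cnc3cc(Cl)ccc3c2N2CCC(C)CC2)cc1C`, gives 86%.

Compound 2 differs from compound 1 by 3,4-dichlorophenyl in place of 3,4-dimethylphenyl on a sulfonyl sulfur. The step that this change made is a number 4 percentage points higher from compound 1 to compound 2 (within the scatter). Compound 3 differs from compound 1 in the core by chloro in place of fluoro on an aromatic carbon, and that step is a number 4 percentage points lower from compound 1 to compound 3 (within the scatter). All three values in this assay lie within the scatter of one another, so no order among them can be read from these numbers.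

Compound 4, `CC1CCN(c2c(S(=O)(=O)c3ccc(Cl)c(Cl)c3)cnc3cc(Cl)ccc23)CC1`, is not yet measured in this assay. Going by the values given here, it differs from compound 3 by 3,4-dichlorophenyl in place of 3,4-dimethylphenyl on a sulfonyl sulfur, which is the same change as the one from compound 1 to compound 2, made on the core of compound 3 rather than on the core of compound 1. Beside the earlier step of a number 4 percentage points higher from compound 1 to compound 2 (within the scatter), the step expected for compound 4 in this assay is a number 4 percentage points higher from compound 3 to compound 4 (within the scatter), resting on the small size of that earlier step and on compound 3 giving 86%. Compound 4 is therefore estimated at 90% in this assay, with a range expected from 82% to 97%.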

Compound 4, a percentage reported as inhibition, at one concentration (the size of the read-out at that concentration, not a potency): 89%
Compound 4: the middle estimate sits 1 percentage points above what was measured, and the stated range covers the measured number.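

In this assay, 3,4-dichlorophenyl in place of 3,4-dimethylphenyl on a sulfonyl sulfur gives a number 3 percentage points higher from compound 3 to compound 4 (within the scatter), and this step agrees with the one on the other core: the same change on two cores in this assay, a number 4 percentage points higher (within the scatter) from compound 1 to compound 2 and a number 3 percentage points higher (within the scatter) from compound 3 to compound 4, 1 percentage points apart, within the scatter of two such steps. On the 3,4-dichlorophenyl side, chloro in place of fluoro on an aromatic carbon gives a number 5 percentage points lower from compound 2 to compound 4 (within the scatter), and this change also reads alike in both settings: the same change on two cores in this assay, a number 4 percentage points lower (within the scatter) from compound 1 to compound 3 and a number 5 percentage points lower (within the scatter) from compound 2 to compound 4, 1 percentage points apart, within the scatter of two such steps. Going by these compounds alone, each change therefore carries between these two cores with no detectable difference in step size, but with every step inside the scatter, this shows only that neither change moved the read-out measurably in these four compounds, not that either has a real direction or that the steps would hold on other cores.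

Still open, on these data alone, is how a methoxy or a nitrile would read in place of the two chloro groups on the phenyl ring. Also open, as far as these compounds go, is how a carboxylic acid or an amine would read in place of the fluoro or chloro on the core.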